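Replacing the 2-carboxy-1H-indol-5-yl group of compound 1

This account rests on a few compounds, and the source may have more. Where it says the series, first, only, none or still open, it means among the compounds named here.

In a functional assay on DU-145 cells (Homo sapiens) for inhibition, read by trypan blue exclusion, with a stated time of 72 h (a higher number here means a weaker inhibitor, a lower number a stronger inhibitor), compound 1 (`Cn1c(=O)c(S(=O)(=O)c2ccc(F)cc2F)cc2cnc(Nc3ccc4[nH]c(C(=O)O)cc4c3)nc21`) gives 10000 nM, the weakest of the three measured compounds. Compound 2 (`COc1ccc(S(=O)(=O)c2cc3cnc(Nc4ccc5[nH]ccc5c4)nc3n(C)c2=O)cc1`) gives 500 nM and compound 3 (`Cn1c(=O)c(S(=O)(=O)c2ccc(F)cc2)cc2cnc(Nc3ccc4[nH]ccc4c3)nc21`) gives 300 nM. Compound 4 (`Cn1ccc2cc(Nc3ncc4cc(S(=O)(=O)c5ccc(F)cc5F)c(=O)n(C)c4n3)ccc21`) has not yet been measured. It differs from compound 1 in one place, on a nitrogen on an aromatic ring: 1-methyl-1H-indol-5-yl in place of 2-carboxy-1H-indol-5-yl on a nitrogen on an aromatic ring.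

For the measured compounds named here, the only measured step, a 1.7-fold lower number from compound 2 to compound 3 (0.22 log units; within the scatter), is fluoro in place of methoxy on an aromatic carbon. Going by the values given here, it lies within the scatter and does not touch the group that changes here, so no measured step tests this change directly. The indirect evidence is that neither compound 2, at 500 nM, nor compound 3, at 300 nM, carries the 2-carboxy-1H-indol-5-yl group, although neither carries the 1-methyl-1H-indol-5-yl group either. The values of compound 4 are therefore expected to lie near theirs. The expected change is a 20-fold lower number from compound 1 to compound 4 (1.30 log units; beyond the scatter), beyond the scatter. For compound 4 the estimate is 500 nM, with an expected range of 120 nM to 2500 nM.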

Compound 4, half-maximal inhibitory concentration: 750 nM
For compound 4 the middle estimate is 1.5-fold (0.18 log units) below the measured one, and the stated range covers the measured number.
By their numbers in this assay, from the lowest: compounds 3, 2 and 4 (each within the scatter of the next, the first and the last beyond it); then compound 1.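

In this assay, replacing the 2-carboxy-1H-indol-5-yl group with the 1-methyl-1H-indol-5-yl group gives a 13-fold lower number from compound 1 to compound 4 (1.12 log units; beyond the scatter) and so provides the first direct test of this group on the shared core. The step is large and lies beyond the scatter, which shows that the number is sensitive to this group, something the earlier fluoro-for-methoxy step could not show. No measurement given here offers an explanation for the size of this step.

The exchange removes the carboxylic acid and adds the methyl group together, so the compounds shown do not separate the contribution of either change. They also leave open how a methyl ester, a primary amide or an aminomethyl group in place of the carboxylic acid would read in this assay.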